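A Second Methyl on the Ring Nitrogen of Compound 3

The source may hold more compounds than are shown below. What is called first, only, known or untested is meant among the compounds shown, and "the series" means these compounds.

Of the compounds shown here, three with a shared core have been measured in an ADME assay on cells (Hepatocyte, Homo sapiens) for metabolic stability, read by LC-MS, with a stated time of 90 min, tested at 1 uM; a lower number here means slower removal, a higher number faster removal of the compound. Compound 1 `CC(C)n1nc(-c2ccc3oc(N)nc3c2)c2c(Br)nc(N)nc21` carries a bromine on the core; in this assay compound 1 gives 55 uL/min. Compound 2 `CC(C)n1nc(-c2ccc3oc(N)nc3c2)c2c(=O)[nH]c(N)nc21` has a carbonyl there instead. For compound 2 this assay returns only a limit, < 5 uL/min, not a number. Compound 3 `CNc1nc2c(c(-c3ccc4oc(N)nc4c3)nn2C(C)C)c(=O)[nH]1` adds one methyl to compound 2. For compound 3 too this assay returns only a limit, < 5 uL/min, so compound 3 stands at the floor of the measurable range rather than at a known number. The step that the two limits leave unreadable from compound 2 to compound 3 therefore cannot be read in size.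

Compound 4 `CC(C)n1nc(-c2ccc3oc(N)nc3c2)c2c(=O)[nH]c(N(C)C)nc21` is the next step along the same line: methyl in place of hydrogen on a nitrogen on an aromatic ring. For the measured compounds named here, the only measured step that resembles it is the one from compound 2 to compound 3, and that step is unreadable, because both compounds sit at the limit of < 5 uL/min in this assay, at which 2 of the 3 values shown sit. No readable step bears on the change, so no direction beyond the scatter can be claimed; the expectation is that compound 4 stays near the floor, with the step of a number no lower from compound 3 to compound 4 (the limit leaves the size open) expected to be small. Compound 4 is therefore expected to give about 5 uL/min in this assay, within a range from 2 uL/min to 15 uL/min, and may again return only a limit.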

Compound 4, intrinsic clearance in a liver preparation (reported as CLH), per the amount of preparation that the assay uses: < 5 uL/min
Compound 4: only a limit was reported; the forecaster's own chance of this, stated with the estimate: 50%; the middle value sits exactly at the limit.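

In this assay compound 4 also returns only a limit, < 5 uL/min. No step among compound 2, compound 3 and compound 4 can be read in size, because all three sit at the same floor: the limit of < 5 uL/min in this assay, at which 3 of the 4 values shown sit.

The compounds shown leave open whether either added methyl changes the rate of removal at all.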